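This account rests on a few compounds, and the source may have more. Where it says the series, first, only, none or still open, it means among the compounds named here.

Compound 1 `Nc1scc(CN2CCN(c3ccccc3C(F)(F)F)CC2)c1C(=O)c1ccc(Cl)cc1` is one of three compounds with a number in a functional assay on CHO cells with adenosine receptor A1 (Homo sapiens) as the target, read by cAMP accumulation and immunoassay, with a stated time of 6 min, tested at 0.01 uM; on this read-out higher numbers stand for a weaker effect at the one concentration tested and lower numbers for a stronger effect. Compound 1 gives 0% in this assay, the second highest of the three numbers. Compound 2 `Nc1scc(CN2CCN(c3cccc(F)c3)CC2)c1C(=O)c1cccc(C(F)(F)F)c1` gives -11%, a number within the scatter of compound 1. Compound 3 `Nc1scc(CN2CCN(c3c(F)cccc3F)CC2)c1C(=O)c1cccc(C(F)(F)F)c1` gives 2.1%, and the gap between compound 3 and compound 1 is within the scatter, while the gap between compound 2 and compound 1 lies beyond it.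

Among the measured compounds shown here, the one step counted between measured compounds is a number 13.1 percentage points higher from compound 2 to compound 3 (beyond the scatter), a change of the aryl group on the ring nitrogen. Compound 4 `Nc1scc(CN2CCN(c3cc(F)cc(F)c3)CC2)c1C(=O)c1ccc(Cl)cc1` differs from compound 1 at the same position: 3,5-difluorophenyl in place of 2-(trifluoromethyl)phenyl on an amine nitrogen in a ring. The step from compound 2 to compound 3 is the only one that bears on this change, and it is modest; all three measured numbers sit close to zero. Compound 4 is therefore expected to show a step of a number 2 percentage points higher from compound 1 to compound 4 (within the scatter) from compound 1, that is, no change beyond the scatter, and its estimated number in this assay is 2%, between -12% and 16%.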

Compound 4, a percentage reported as activity, at one concentration (the size of the read-out at that concentration, not a potency): -13%
For compound 4 the middle estimate is 15 percentage points above the measured one, and the stated range ends above it.
By their numbers in this assay, from the lowest: compounds 4 and 2 (each within the scatter of the next); then compounds 1 and 3 (each within the scatter of the next).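

In this assay, among the compounds shown here, the step of a number 13 percentage points lower from compound 1 to compound 4 (beyond the scatter) is the first one seen on the core of compound 1, and it goes to a lower number, which stands for a stronger effect at the one concentration tested. Set beside a number 13.1 percentage points higher from compound 2 to compound 3 (beyond the scatter), which runs the other way on a different core, it shows that exchanging the aryl group on this amine nitrogen in a ring can move the number in either direction, though both steps are modest. Nothing shown here accounts for the shift on going from 2-(trifluoromethyl)phenyl to 3,5-difluorophenyl.

Going by these compounds, it remains open whether 3,5-difluorophenyl would lower the number in the same way on the core of compound 2. Also open is how a pyridyl or a benzyl group on this nitrogen would behave, and a single concentration gives no potency for any of these compounds.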